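Notes on the aryl exchange from compound 2 to compound 3

This account rests on a few compounds, and the source may have more. Where it says the series, first, only, none or still open, it means among the compounds named here.

Values so far in a functional assay on HT-29 cells (Homo sapiens) for antiproliferative activity, read by MTT assay, with a stated time of 96 h; a higher number here means a weaker inhibitor, a lower number a stronger inhibitor:
compound 1 `CCCCc1ccc(N2C(=O)NC3(CSC4=C3C(=O)c3ncccc3C4=O)C2=O)cc1`: 50 nM
compound 2 `CC(C)(C)c1ccc(N2C(=O)NC3(CSC4=C3C(=O)c3ncccc3C4=O)C2=O)cc1`: 150 nM

Compound 2 stands at the higher of the two numbers, compound 1 at the lower. For the measured compounds named here, the single measured step between them, a 3.0-fold higher number from compound 1 to compound 2 (0.48 log units; beyond the scatter), comes from tert-butyl in place of butyl on an aromatic carbon, a modest change confined to the alkyl substituent of the aryl group.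

Compound 3 `O=C1C2=C(C(=O)c3ncccc31)C1(CS2)NC(=O)N(c2ccncc2)C1=O` is the next candidate. Its difference from compound 2 is counted as pyridin-4-yl in place of 4-(tert-butyl)phenyl on an amide-type nitrogen in a ring.

The recorded step bears on this change only indirectly: it compares two alkyl groups on the same aryl ring, whereas the present move removes the whole 4-(tert-butyl)phenyl and puts pyridin-4-yl in its place. Going by the values given here, the data contain no example of such a ring exchange, so the direction rests on weak footing. Given that the aryl substituent already shifted the number beyond the scatter in a 3.0-fold higher number from compound 1 to compound 2 (0.48 log units; beyond the scatter), a larger shift toward a higher number is anticipated here, with wide uncertainty.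

For compound 3 the expected value in this assay is 500 nM, estimated within 100 nM to 2500 nM. This estimate corresponds to an expected 3.3-fold higher number from compound 2 to compound 3 (0.52 log units; beyond the scatter).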

Compound 3, half-maximal inhibitory concentration: 2 nM
Beside the measured number, compound 3's estimate is 250-fold (2.40 log units) above it; the whole stated range lies above it.
By their numbers in this assay, from the lowest: compound 3; then compound 1; then compound 2.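

In this assay the aryl group as a whole on the amide-type nitrogen proves a much larger lever than its alkyl substituent: pyridin-4-yl in place of 4-(tert-butyl)phenyl gives a 75-fold lower number from compound 2 to compound 3 (1.88 log units; beyond the scatter) and pyridin-4-yl in place of 4-butylphenyl gives a 25-fold lower number from compound 1 to compound 3 (1.40 log units; beyond the scatter) while the exchange of alkyl groups alone gave only a 3.0-fold higher number from compound 1 to compound 2 (0.48 log units; beyond the scatter) in the earlier pair. The position therefore does not require a large all-carbon aryl group with an alkyl substituent, since the entering pyridin-4-yl has fewer heavy atoms and a ring nitrogen, and compound 3 is the most potent of the three in this series. Nothing on hand bears on why the number falls so far at this position.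

The exchange alters ring atoms and removes the alkyl group in one move, so unsubstituted phenyl, pyridin-3-yl and pyridin-2-yl remain the comparisons that would separate the ring nitrogen and its place from the loss of the alkyl group. Also open, as far as these compounds go, is whether the low number survives an amine or a methoxy group on the pyridine ring.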